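This account rests on a few compounds, and the source may have more. Where it says the series, first, only, none or still open, it means among the compounds named here.

Measured so far in a functional assay on MOLT-3 cells (Homo sapiens); on this read-out lower numbers stand for stronger inhibition and higher numbers for weaker inhibition:
compound 1 `CCCCCCSC[C@H](NC(C)=O)C(=O)CCl`: 700 nM
compound 2 `CCCCCCCCCCCCSC[C@H](NC(C)=O)C(=O)CCl`: 2300 nM

Of these two numbers, the higher belongs to compound 2, at 2300 nM, which means weaker inhibition in this assay. Among the measured compounds shown here, its only neighbour, compound 1, stands at 700 nM, a gap beyond the scatter.

Compound 3 `CCCCCCCCCCCCCCCCCCSC[C@H](NC(C)=O)C(=O)CCl` differs from compound 2 in one place: hexyl in place of hydrogen on a saturated chain carbon, ten or more bonds along the chain from a sulfur. This is hexyl in place of hydrogen on a saturated chain carbon, ten or more bonds along the chain from a sulfur.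

For the measured compounds named here, the only measured step that bears on this change is a 3.3-fold higher number from compound 1 to compound 2 (0.52 log units; beyond the scatter), a modest one. It is the same exchange of hydrogen for hexyl, made closer to the sulfur. One step is thin evidence, and the data do not show whether the trend continues as the chain grows. Even so, a further modest rise in the number is the likeliest outcome, of about the same size, with no reversal expected. The expected change is a 2.8-fold higher number from compound 2 to compound 3 (0.45 log units; beyond the scatter). The estimate for compound 3 is 6500 nM, with an expected range from 2500 nM to 20000 nM.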

Compound 3, half-maximal inhibitory concentration: > 100000 nM
Compound 3 ended at the assay's limit; the forecaster's own chance of this, stated with the estimate: 10%; middle value at least 15-fold (1.18 log units) away from the limit.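

In this assay, the second extension by hexyl weighs far more than the first: an at least 43-fold higher number from compound 2 to compound 3 (1.63 log units; beyond the scatter), against a 3.3-fold higher number from compound 1 to compound 2 (0.52 log units; beyond the scatter). For compound 3 the value > 100000 nM is a limit of the assay and not a number: the limit of > 100000 nM in this assay, at which 1 of the 3 values shown sits. The same exchange of hydrogen for hexyl therefore does not repeat the modest rise of the earlier step, although the number goes up at both steps and none of the three compounds goes against that direction.

From the compounds shown here alone, it remains open whether the rise between compound 2 and compound 3 is gradual or abrupt, which a pentadecyl chain in place of the chain of compound 2 could show, and whether a butyl chain would give a lower number than compound 1 at 700 nM. Also open, going by these compounds, is whether a long chain carrying a carboxylic acid or an amine would behave as compound 3 does in this assay.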